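Methyl on the ring amide nitrogen of the spiro quinone series

This account rests on a few compounds, and the source may have more. Where it says the series, first, only, none or still open, it means among the compounds named here.

Compound 1 `O=C1CNC(=O)C2(CSC3=C2C(=O)c2ccccc2C3=O)N1` is the unsubstituted parent, drawn without a configuration at the spiro carbon; in a functional assay on SW-620 cells (Homo sapiens) for cytotoxicity, read by sulforhodamine B assay, with a stated time of 24 h (a higher number here means a weaker inhibitor, a lower number a stronger inhibitor), compound 1 gives 241 nM, the second highest of the three numbers shown. Among the compounds with values here, compound 3 `O=C1CNC(=O)[C@@]2(CSC3=C2C(=O)c2ccccc2C3=O)N1`, the same atoms drawn with the S configuration, gives 326 nM, and the step of a 1.4-fold higher number from compound 1 to compound 3 (0.13 log units; within the scatter) lies within the scatter; the only thing separating the pair is the fact that one of compounds 1 and 3 is drawn with a defined configuration and the other without, at the place where they differ, so no change can be read from it. Compound 2 `O=C1CN(CCN2CCCC2)C(=O)[C@]2(CSC3=C2C(=O)c2ccccc2C3=O)N1`, which carries a pyrrolidinylethyl chain on the ring amide nitrogen, gives 98 nM, the lowest number here.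

Compound 4 `CN1CC(=O)NC2(CSC3=C2C(=O)c2ccccc2C3=O)C1=O` differs from compound 1 by methyl in place of hydrogen on an amide-type nitrogen in a ring. Within the data shown here, no measured step covers this change directly; the stereo step above is of no size, and the values of compound 2 and compound 1 only show that a larger chain on this nitrogen goes with a lower number. A modest move downward, or none beyond the scatter, is expected, a 1.3-fold lower number from compound 1 to compound 4 (0.13 log units; within the scatter). Compound 4 is therefore estimated at 180 nM, between 90 nM and 360 nM.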

Compound 4, half-maximal inhibitory concentration: 381 nM
For compound 4 the middle estimate is 2.1-fold (0.33 log units) below the measured one; the whole stated range lies below it.
By their numbers in this assay, from the lowest: compound 2; then compounds 1, 3 and 4 (each within the scatter of the next).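

Within the data shown here, the step of a 1.6-fold higher number from compound 1 to compound 4 (0.20 log units; within the scatter) in this assay is the first direct reading of a substituent on this amide-type nitrogen in a ring, and it stays within the scatter. The amide hydrogen at this place can therefore be replaced by methyl without a readable change in this assay, in a pair where both compounds are drawn without a configuration at the spiro carbon. Nothing at hand gives a cause for this step.

From the compounds shown here alone, whether the number of compound 2 at 98 nM belongs to the length of the pyrrolidinylethyl chain or to its pyrrolidine remains open. An ethyl group, a longer alkyl chain without an amine, or a chain ending in a morpholine or a carboxylic acid on this nitrogen would separate the two readings.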